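Cytotoxicity limits: compound 2 to compound 3

This account rests on a few compounds, and the source may have more. Where it says the series, first, only, none or still open, it means among the compounds named here.

In an ADME assay on MT4 cells (Homo sapiens) for cytotoxicity, read by MTT assay (on this read-out lower numbers stand for higher toxicity in this test and higher numbers for lower toxicity in this test), compound 1 (`CC(=O)CSc1nc(Cc2c(F)cccc2F)cc(=O)[nH]1`) gives only a limit (> 81000 nM). Compound 2 (`Cc1cc(C)cc(CSc2nc(Cc3c(F)cccc3F)c(C)c(=O)[nH]2)c1`) also stands only at a limit (> 65000 nM). Compound 3 (`Cc1c(Cc2c(F)cccc2F)nc(SC(C)C)[nH]c1=O`) has isopropyl in place of 3,5-dimethylbenzyl on a sulfur. Within the data shown here, no measured step is available to size this change. The step expected in this assay is none beyond the usual scatter (a step that the limit leaves unreadable from compound 2 to compound 3). Compound 3 is estimated at 84000 nM as a working value, with an expected range from 35000 nM to 130000 nM and a good chance of another limit.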

Compound 3, half-maximal cytotoxic concentration: > 77000 nM
Compound 3: a limit, no number; the forecaster's own chance of this, stated with the estimate: 75%; the middle value does not contradict the limit.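

Among these compounds, compound 2 and compound 3 both stand only at limits in this assay; no step between them can be read. The compounds shown leave open whether isopropyl in place of 3,5-dimethylbenzyl on a sulfur shifts the half-maximal cytotoxic concentration at all.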